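A Longer Acyl Chain on a Shared Core in Buffer

This account rests on a few compounds, and the source may have more. Where it says the series, first, only, none or still open, it means among the compounds named here.

Measured compounds:
compound 1 `CC(C)C(=O)OCOC(=O)C1=C(S[C@@H]2CN[C@H](C(=O)Nc3cccc(C(=O)O)c3)C2)[C@H](C)[C@@H]2[C@@H]([C@@H](C)O)C(=O)N12`: > 95%
compound 2 `CC(C)OC(=O)c1cccc(NC(=O)[C@@H]2C[C@H](SC3=C(C(=O)O)N4C(=O)[C@H]([C@@H](C)O)[C@H]4[C@H]3C)CN2)c1`: > 95%

In a physicochemical assay for metabolic stability, read by LC-MS, in phosphate buffer, with a stated time of 3 h, at pH 7.4, tested at 50 uM (on this read-out lower numbers stand for a less stable compound and higher numbers for a more stable compound), compound 1 gives > 95%, which is a limit of the assay and not a number. In this assay compound 2 gives > 95%, again a limit rather than a number. Both values therefore sit at the limit of > 95% in this assay, at which 2 of the 2 values shown sit, so compound 1 stands at the upper edge of what this assay can report, and nothing here separates it from compound 2.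

Compound 3 `CCC(CC)C(=O)OCOC(=O)C1=C(S[C@@H]2CN[C@H](C(=O)Nc3cccc(C(=O)O)c3)C2)[C@H](C)[C@@H]2[C@@H]([C@@H](C)O)C(=O)N12` keeps the shared core of compound 1 and differs from it in one place: pentan-3-yl in place of isopropyl on a carbonyl carbon. Among the measured compounds shown here, no step between two measured compounds is available, so there is no measured guide to the size of this change. The expected step is a step that the limit leaves unreadable from compound 1 to compound 3, that is, none beyond the usual scatter of this assay. Compound 3 is accordingly estimated at 96%, with a range from 88% to 100%, most likely reported again as a limit.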

Compound 3, percent of the compound remaining: > 95%
Compound 3 ended at the assay's limit; the forecaster's own chance of this, stated with the estimate: 80%; the middle value does not contradict the limit.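

In this assay compound 3 gives > 95%, which is a limit of the assay and not a number. No step from compound 1 to compound 3 can be read: the limit of > 95% in this assay, at which 3 of the 3 values shown sit.

The compounds shown leave open whether pentan-3-yl in place of isopropyl on a carbonyl carbon changes the percent of compound remaining at all.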